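Sigma-2 binding: inverting the ring stereocentre of compound 3

The source may report more compounds than this note shows. Statements on the series, on what has been measured and on what is new or still open speak of the compounds shown alone.

Three compounds have numbers in an assay on membranes from HEK293 cells for displacement of a labelled ligand from Sigma intracellular receptor 2 (Homo sapiens); a lower number here means a stronger inhibitor, a higher number a weaker inhibitor. Compound 1 `COc1ccc(CO[C@H]2CCCN(Cc3ccc(C)cc3)C2)cc1F` gives 40 nM. Compound 2 `Cc1c(Cl)cccc1NC(=O)CN1CCC2(CCCN2Cc2ccc(F)c(F)c2)C1` gives 43 nM. Compound 3 `COc1ccc(CN2CCC[C@H](OCc3ccc(F)c(C)c3)C2)cc1F` gives 123 nM, the highest of the three; its gap to compound 2 and to compound 1 lies beyond the scatter, so compound 3 is the weakest inhibitor of the set on these numbers.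

Compound 4 `COc1ccc(CN2CCC[C@@H](OCc3ccc(F)c(C)c3)C2)cc1F` is the next point. Against compound 3 the difference is the two compounds have the same atoms and bonds and differ only in configuration as drawn: 1 of 1 stereo elements differ; a stereocentre at a saturated ring carbon is drawn S in compound 3 and R in compound 4. Among the compounds with values here, no step between two measured compounds of this kind is available, so there is no precedent for the size of the change; the only guide is that compound 3 sits at the weak end and its partner can plausibly move either way. The expectation is a moderate step toward a lower number, with wide uncertainty in both directions.

The expected step from compound 3 to compound 4 in this assay is a 1.5-fold lower number from compound 3 to compound 4 (0.19 log units; within the scatter). For compound 4 the estimate is 80 nM, in a range from 20 nM to 400 nM.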

Compound 4, inhibition constant: 206 nM
Compound 4: the middle estimate sits 2.6-fold (0.41 log units) below what was measured; the measured number falls inside the stated range.
By their numbers in this assay, from the lowest: compounds 1 and 2 (each within the scatter of the next); then compounds 3 and 4 (each within the scatter of the next).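

In this assay the change from S to R at the saturated ring carbon gives a 1.7-fold higher number from compound 3 to compound 4 (0.22 log units; within the scatter). Within the data shown here, this is the first step with one place changed, and it shows that, for this pair, the two drawn configurations at this carbon are not separated in this assay. The comparison reads the stereocentre alone, with no other structural change mixed into it: the fact that compounds 3 and 4 differ only in the configuration as drawn.

From the compounds shown here alone, whether the configuration at this carbon stays this little felt with other groups on the ring remains open, for instance if an amide or a longer chain takes the place of the benzyl ether. Also open, going by these compounds, is whether the same holds when the fluoro and methyl groups on the benzyl ring give way to a nitrile or a carboxylic acid.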